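Chloro for methoxy on a weakly cytotoxic core

The source may hold more compounds than are shown below. What is called first, only, known or untested is meant among the compounds shown, and "the series" means these compounds.

Measured so far:
Compound 1, `COc1ccc(-c2ccc(C(=O)Nc3ccc(Oc4ccnc5[nH]ccc45)cc3)nc2)cc1`, in a functional assay on MCF7 cells (Homo sapiens) for cytotoxicity, read by MTT assay, with a stated time of 72 h (on this read-out higher numbers stand for weaker inhibition and lower numbers for stronger inhibition), gives > 10000 nM, a limit of the assay rather than a number.
Compound 2, `CCc1ccc(-c2ccc(C(=O)Nc3ccc(Oc4ccnc5[nH]ccc45)cc3)nc2)cc1`, gives > 10000 nM, likewise a limit.
Compound 3, `COc1ccc(-c2ccnc(C(=O)Nc3ccc(Oc4ccnc5[nH]ccc45)cc3)c2)cc1`, gives 8210 nM.

Among the compounds with values here, compound 3 thus stands on the only real number among the three; compound 1 and compound 2 both sit at the limit of > 10000 nM in this assay, at which 2 of the 3 values shown sit. Within the data shown here, the single one-place step among the measured compounds, a step that the two limits leave unreadable from compound 1 to compound 2, runs between two limits and has no readable size, so it tells nothing about how a change at that position moves the read-out.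

Compound 4, `O=C(Nc1ccc(Oc2ccnc3[nH]ccc23)cc1)c1cc(-c2ccc(Cl)cc2)ccn1`, differs from compound 3 by chloro in place of methoxy on an aromatic carbon. Among the measured compounds shown here, no measured step involves chloro, and the only step at this position is the unreadable one from compound 1 to compound 2, so there is no precedent for the direction or size of this change. The value of compound 3 is the sole anchor. The step of a 1.1-fold lower number from compound 3 to compound 4 (0.04 log units; within the scatter) is therefore expected to stay within the scatter, with a real chance that compound 4 returns only a limit. Compound 4 is estimated at 7500 nM, with a range from 2500 nM to 20000 nM.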

Compound 4, half-maximal inhibitory concentration: > 10000 nM
Compound 4 gave a limit, no number; the forecaster's own chance of this, stated with the estimate: 40%; at least 1.3-fold (0.12 log units) between middle value and limit.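

In this assay, within the data shown here, the change from 4-methoxyphenyl to 4-chlorophenyl gives the first step at this position with a readable size, an at least 1.2-fold higher number from compound 3 to compound 4 (0.08 log units; that floor lies within the scatter), whereas the earlier step between two limits cannot be read. Compound 4 gives > 10000 nM, a limit of the assay and not a number. Chloro in place of methoxy therefore brings no lower number on this core, although the size of any rise stays unknown, and the floor of the step does not separate the two groups beyond the scatter, while the limit now holds most of the series: the limit of > 10000 nM in this assay, at which 3 of the 4 values shown sit.

Going by these compounds, what remains open is whether any group on this aromatic carbon can move the read-out clearly away from the value of compound 3, since only methoxy gives a number here and the true value of compound 4 is hidden behind its limit. An amine, a carboxylic acid or a longer chain such as propyl at this place would show whether the position responds at all in this assay.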